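Three Fluorines on the Amide Ring of Compound 1

The source may report more compounds than this note shows. Statements on the series, on what has been measured and on what is new or still open speak of the compounds shown alone.

Compound 1 `CC(C)c1cccc(C(C)C)c1OC(=O)CC(=O)Nc1ccccc1` gives > 5000 nM in an assay on microsomes from intestine for inhibition of acyl-CoA:cholesterol acyltransferase (Oryctolagus cuniculus); a lower number here means a stronger inhibitor, a higher number a weaker inhibitor.
Compound 2 `COc1cc(OC)c(OC(=O)CC(=O)Nc2c(C(C)C)cccc2C(C)C)c(OC)c1` gives 320 nM in this assay.
Compound 3 `CCCCCCCCCCCCCCC(C)OC(=O)CC(=O)Nc1c(C(C)C)cccc1C(C)C` gives 11 nM in this assay.

Compound 1 stands apart from the other two: its result is a limit of the assay and not a number, (the limit of > 5000 nM in this assay, at which 1 of the 3 values shown sits). Compound 2 and compound 3 both carry a different group on the ester side of the shared core, and both give real numbers, compound 3 with the lower of the two. Neither of them is one simple change away from compound 1, so those two values say nothing direct about the amide side.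

Compound 4 `CC(C)c1cccc(C(C)C)c1OC(=O)CC(=O)Nc1c(F)cc(F)cc1F` differs from compound 1 by 2,4,6-trifluorophenyl in place of phenyl on an amide-type nitrogen. Among the measured compounds shown here, no measured pair in this set shows what this change does. Since compound 1 sits at the limit, the step from it can be followed in only one direction, toward a number. The expectation is a modest step, if any, so that compound 4 most likely remains a weak inhibitor, with a fair chance that it too returns only a limit; the estimated step is a step that the limit leaves unreadable from compound 1 to compound 4. For compound 4 the estimate is 6000 nM, within a range from 1500 nM to 25000 nM.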

Compound 4, half-maximal inhibitory concentration: > 5000 nM
Compound 4 ended at the assay's limit; the forecaster's own chance of this, stated with the estimate: 55%; the middle value does not contradict the limit.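

Compound 1 and compound 4 both end at a limit of this assay and not at a number, so no step between these two compounds can be read: the limit of > 5000 nM in this assay, at which 2 of the 4 values shown sit.

The compounds shown leave open whether 2,4,6-trifluorophenyl in place of phenyl on an amide-type nitrogen changes the inhibition at all, and in which direction.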